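This account rests on a few compounds, and the source may have more. Where it says the series, first, only, none or still open, it means among the compounds named here.

Measured so far:
- compound 1, `CO[C@H]1CC[C@@H](Nc2cc(NCc3cnccc3C(F)(F)F)ncc2C#N)CC1`: 58 nM
- compound 2, `N#Cc1cnc(NCc2ccccc2C(F)(F)F)cc1N[C@H]1C[C@H](C(N)=O)C1`: 5000 nM
- compound 3, `CC1(C)C[C@H](Nc2cc(NCc3cnccc3C(F)(F)F)ncc2C#N)CC(C)(C)[C@@H]1O`: 12 nM

In an assay on isolated protein for inhibition of protein kinase C theta type (Homo sapiens), read by TR-FRET, with a stated time of 2 h (on this read-out lower numbers stand for stronger inhibition and higher numbers for weaker inhibition), compound 1 gives 58 nM, the second highest of the three numbers. Compound 3 gives 12 nM, a lower number that lies beyond the scatter, and compound 2 gives 5000 nM, a much higher number, also beyond the scatter. No pair among these three differs in a single place, so the gaps are read only as what the two values show.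

Compound 4, `CC1(C)C[C@@H](Nc2cc(NCc3cnccc3C(F)(F)F)ncc2C#N)CC[C@H]1O`, has not yet been measured. It differs from compound 1 in one place: 4-hydroxy-3,3-dimethylcyclohexyl in place of 4-methoxycyclohexyl on a nitrogen on an aromatic ring. Compound 4 shares with compound 3 a hydroxyl on the ring attached to that nitrogen, where compound 1 carries a methoxy group. Given that compound 3 gives 12 nM and compound 1 gives 58 nM, the step from compound 1 to compound 4 in this assay is expected to be downward and modest, estimated as a 2.3-fold lower number from compound 1 to compound 4 (0.37 log units; beyond the scatter), possibly just beyond the scatter. Compound 4 is therefore expected to give about 25 nM, within a range of 8 nM to 80 nM.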

Compound 4, half-maximal inhibitory concentration: 120 nM
Compound 4: middle estimate off by 4.8-fold (0.68 log units), on the low side; the whole stated range lies below it.
By their numbers in this assay, from the lowest: compound 3; then compound 1; then compound 4; then compound 2.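

In this assay, among these compounds, 4-hydroxy-3,3-dimethylcyclohexyl in place of 4-methoxycyclohexyl on a nitrogen on an aromatic ring gives a 2.1-fold higher number from compound 1 to compound 4 (0.32 log units; beyond the scatter), the first reading at this position between two compounds that differ in one place. The entering group carries a hydrogen-bond donor where the leaving group carries none, and in this pair that change goes with a higher number, not a lower one. No measurement shown here accounts for this step.

Among the compounds shown here, the single step swaps methoxy for hydroxyl and adds the 3,3-dimethyl pair together, so the share of each cannot be separated, and a plain 4-hydroxycyclohexyl would be needed to part them. On these data alone, how a 4-aminocyclohexyl or a 4-carboxycyclohexyl group would read at this position also stays open.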